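From bromo to (benzylamino)methyl on the shared core

The source may hold more compounds than are shown below. What is called first, only, known or untested is meant among the compounds shown, and "the series" means these compounds.

In an ADME assay on HEK-293T cells (Homo sapiens) for cytotoxicity, read by luminescence, with a stated time of 24 h (a lower number here means that less compound is tolerated, a higher number that more compound is tolerated), compound 1 `CCCNC(=O)C1CCN(C(=O)c2cc3sccc3n2Cc2ccc(OC)cc2)CC1` gives 18800 nM and compound 2 `COc1ccc(Cn2c(C(=O)N3CCC(C(=O)NCCC(C)C)CC3)cc3sccc32)cc1` gives 30900 nM. The step between these two is a 1.6-fold higher number from compound 1 to compound 2 (0.22 log units; within the scatter).

Compound 3 `CCCNC(=O)C1CCN(C(=O)c2cc3sc(Br)cc3n2Cc2ccc(OC)cc2)CC1` reads > 100000 nM, which is a limit of the assay and not a number. Compound 3 thus sits at the limit of > 100000 nM in this assay, at which 1 of the 3 values shown sits. Bromo in place of hydrogen on an aromatic carbon is the one change that sets it apart from compound 1, and that step is an at least 5.3-fold higher number from compound 1 to compound 3 (0.72 log units; beyond the scatter).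

Compound 4 `CCCNC(=O)C1CCN(C(=O)c2cc3sc(CNCc4ccccc4)cc3n2Cc2ccc(OC)cc2)CC1` carries (benzylamino)methyl in place of bromo on an aromatic carbon of a five-membered aromatic ring with 1 sulfur, next to the ring sulfur ((benzylamino)methyl in place of bromo on an aromatic carbon). Among the measured compounds shown here, no measured step shows what this entering group does. The bromo does leave, however, so compound 1 at 18800 nM is the nearest guide, and the expectation is that most of an at least 5.3-fold higher number from compound 1 to compound 3 (0.72 log units; beyond the scatter) is given back. The chain step a 1.6-fold higher number from compound 1 to compound 2 (0.22 log units; within the scatter) bears on this only weakly, as it lies elsewhere on the molecule.

A move to a lower number in this assay is therefore expected, with the estimated step being an at least 5.0-fold lower number from compound 3 to compound 4 (0.69 log units; beyond the scatter). For compound 4 the estimated value is 20000 nM, with an expected range of 6000 nM to 80000 nM.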

Compound 4, half-maximal cytotoxic concentration: 46800 nM
Compound 4: the middle estimate sits 2.3-fold (0.37 log units) below what was measured, within the range that was stated.
By their numbers in this assay, from the lowest: compounds 1, 2 and 4 (each within the scatter of the next, the first and the last beyond it). At a limit, above all of these: compound 3.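

In this assay, the aromatic carbon next to the ring sulfur now has a second group to its record, and the higher number seen with bromo is no longer tied to bromo alone. The step for (benzylamino)methyl in place of hydrogen is a 2.5-fold higher number from compound 1 to compound 4 (0.40 log units; beyond the scatter), so a group that brings a six-membered aromatic ring of carbon only and a nitrogen also moves the number up from the unsubstituted shared core. The step for (benzylamino)methyl in place of bromo is an at least 2.1-fold lower number from compound 3 to compound 4 (0.32 log units; beyond the scatter), which separates the two groups at this position, but its full size cannot be read because compound 3 stands at a limit: the limit of > 100000 nM in this assay, at which 1 of the 4 values shown sits.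

The compounds shown do not tell whether the nitrogen or the benzene ring of the entering group accounts for the step from the unsubstituted core, which a plain aminomethyl or a benzyl group at the same carbon would help to separate. As far as these compounds go, it also stays open how other groups on this carbon would read, such as chloro, a methyl or a carboxylic acid, and whether the effect holds with the isopentyl-type amide chain of compound 2.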